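The source may report more compounds than this note shows. Statements on the series, on what has been measured and on what is new or still open speak of the compounds shown alone.

Compound 1 `Cn1c(-c2ccc(C#N)cc2)cnc1NC(=O)c1ncc[nH]1` and compound 2 `Cn1c(-c2ccccc2)cnc1NC(=O)c1ncc[nH]1` share one core. In a toxicity assay on THP-1 cells (Homo sapiens) for inhibition (a lower number here means that less compound is tolerated, a higher number that more compound is tolerated), compound 1 reaches only the limit > 100000 nM. In this assay compound 2 also reaches only the limit > 100000 nM, so where it stands is known as a limit alone. The step that the two limits leave unreadable from compound 1 to compound 2 cannot be read because of the limit of > 100000 nM in this assay, at which 2 of the 2 values shown sit. Compound 3 `Cn1c(-c2ccccc2)cnc1NC(=O)c1ccc(Cl)cc1` differs from compound 2 by 4-chlorophenyl in place of 1H-imidazol-2-yl on a carbonyl carbon. For the measured compounds named here, no measured step bears on this change, and the one measured step is unreadable, so no step beyond the scatter is expected in this assay. Compound 3 is expected to give 100000 nM, between 25000 nM and 300000 nM, an expected step of a number no higher from compound 2 to compound 3 (the limit leaves the size open).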

Compound 3, half-maximal cytotoxic concentration: > 100000 nM
Compound 3 was reported as a limit (the forecaster's own chance of this, stated with the estimate: 60%); the middle value lies on the limit itself.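

In this assay, for the compounds shown here, the step between compound 2 and compound 3 cannot be read, and no new step emerges: the limit of > 100000 nM in this assay, at which 3 of the 3 values shown sit. The compounds shown leave open where compound 1, compound 2 and compound 3 actually stand, and what either change does to tolerance.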